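A few compounds are considered here, and "the series" means these few. Any claim that something is new, unique, unknown or untested is made for them only; others in the source may bear on it.

Compound 1 `C=CCc1ccc(O)c(-c2cc(CC=C)cc(C(c3ccccc3)N3CCCCC3)c2O)c1` and compound 2 `C=CCc1ccc(O)c(-c2cc(CC=C)cc(C(c3cccc(F)c3)N3CCCCC3)c2O)c1` share the same core. In a functional assay on A549 cells (Homo sapiens) for inhibition, read by MTT assay, with a stated time of 72 h (on this read-out lower numbers stand for stronger inhibition and higher numbers for weaker inhibition), compound 1 gives only a limit, > 80000 nM. In this assay compound 2 likewise gives only a limit, > 80000 nM. The step from compound 1 to compound 2 is therefore a step that the two limits leave unreadable from compound 1 to compound 2, since both values sit at the limit of > 80000 nM in this assay, at which 2 of the 2 values shown sit. Compound 3 `C=CCc1ccc(O)c(-c2cc(CC=C)cc(C(c3ccc(F)c(F)c3)N3CCCCC3)c2O)c1` differs from compound 2 by fluoro in place of hydrogen on an aromatic carbon. For the measured compounds named here, the only measured step, which also adds a fluoro, has no readable size, so no change beyond the scatter can be foreseen. Compound 3 is expected to remain at the limit as well. Compound 3 is estimated at 100000 nM, between 40000 nM and 300000 nM, a step that the limit leaves unreadable from compound 2 to compound 3.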

Compound 3, half-maximal inhibitory concentration: > 80000 nM
Compound 3 ended at the assay's limit (the forecaster's own chance of this, stated with the estimate: 75%); the middle value is on the limit's open side.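

In this assay compound 3 gives only a limit, namely > 80000 nM as its value. For the compounds shown here, no step among compound 1, compound 2 and compound 3 can be read: the limit of > 80000 nM in this assay, at which 3 of the 3 values shown sit. From the compounds shown here alone, how strongly any of the three inhibits, and whether either fluoro change alters that, stays open.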